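Pyrrolidine for isopropylamine on an N-methyl benzimidazole core

A few compounds are considered here, and "the series" means these few. Any claim that something is new, unique, unknown or untested is made for them only; others in the source may bear on it.

Compound 1 `O=C(COc1ccc(C(F)(F)F)cc1)Nc1ccc2nc(N3CCCC3)[nH]c2c1`: 9 nM
Compound 2 `CC(C)Nc1nc2ccc(NC(=O)COc3ccc(C(F)(F)F)cc3)cc2n1C`: 101 nM
Compound 3 `Cc1nc(N(C)CCN(C)C)nc2ccc(NC(=O)COc3ccc(C(F)(F)F)cc3)cc12`: 164 nM

In a functional assay for inhibition of melanin-concentrating hormone receptor 1 (Homo sapiens), read by calcium flux (on this read-out lower numbers stand for stronger inhibition and higher numbers for weaker inhibition), compound 2 gives 101 nM. Among the three measured compounds its number lies within the scatter of compound 3, which gives 164 nM, and well beyond the scatter of compound 1, which gives 9 nM. Compound 4 `Cn1c(N2CCCC2)nc2ccc(NC(=O)COc3ccc(C(F)(F)F)cc3)cc21` has not yet been measured. It differs from compound 2 by pyrrolidin-1-yl in place of isopropylamino on an aromatic carbon. For the measured compounds named here, no measured pair traces this exact change, so the expected step rests on compound 1, which also bears pyrrolidin-1-yl and gives 9 nM. For compound 4 a step toward a lower number in this assay is expected, of size a 2.5-fold lower number from compound 2 to compound 4 (0.40 log units; beyond the scatter), beyond the scatter. Compound 4 is estimated at 40 nM, with a range from 10 nM to 150 nM.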

Compound 4, half-maximal inhibitory concentration: 9 nM
Beside the measured number, compound 4's estimate is 4.4-fold (0.65 log units) above it; measured number outside the range, below it.
By their numbers in this assay, from the lowest: compounds 1 and 4 (each within the scatter of the next); then compounds 2 and 3 (each within the scatter of the next).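

In this assay, for the compounds shown here, pyrrolidin-1-yl in place of isopropylamino gives an 11-fold lower number from compound 2 to compound 4 (1.05 log units; beyond the scatter) at this carbon between two ring nitrogen atoms, the first direct reading of this change and a large one. Methyl in place of hydrogen on the aromatic nitrogen gives no change at the digits printed from compound 1 to compound 4 (within the scatter) and so, with pyrrolidin-1-yl present, the methyl shifts nothing beyond the scatter. Nothing measured here speaks to the reason for the large step. On these data alone, whether the isopropylamino compound without the methyl would give a similar number remains open. So does the response at this carbon to piperidin-1-yl, morpholin-4-yl or dimethylamino.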